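This account rests on a few compounds, and the source may have more. Where it says the series, first, only, none or still open, it means among the compounds named here.

Compound 1 `Brc1cccc(Br)c1N(CC1CC1)C1=NCCN1` sits at the most polar end of three close relatives. In a physicochemical assay for lipophilicity (a higher number here means a more lipophilic compound, a lower number a more polar compound), compound 1 gives -1.12, while compound 2 `CCN(C1=NCCN1)c1c(Br)cccc1Br` gives -1.01 and compound 3 `C#CCN(C1=NCCN1)c1c(Br)cccc1Br` gives -0.18. The swap to methyl moved the number a number 0.11 log units higher from compound 1 to compound 2 (within the scatter); the swap to ethynyl moved it a number 0.94 log units higher from compound 1 to compound 3 (beyond the scatter). Compound 4 `Brc1cccc(Br)c1N(Cc1ccco1)C1=NCCN1` varies the same spot: furan-2-yl in place of cyclopropyl on a saturated chain carbon bound to a nitrogen on an aromatic ring. Within the data shown here, no measured step exchanges cyclopropyl for an aromatic ring, so both earlier steps are only rough guides. A small rise is expected for compound 4, a number 0.32 log units higher from compound 1 to compound 4 (beyond the scatter), in this assay. The estimate for compound 4 is therefore -0.8, with a likely range from -1.4 to -0.2.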

Compound 4, distribution coefficient: -0.52
Compound 4: middle estimate off by 0.28 log units, on the low side; the measured number falls inside the stated range.
By their numbers in this assay, from the lowest: compounds 1 and 2 (each within the scatter of the next); then compound 4; then compound 3.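

Furan-2-yl brings the first aromatic ring to this position, and in this assay the number comes out a number 0.60 log units higher from compound 1 to compound 4 (beyond the scatter) and a number 0.49 log units higher from compound 2 to compound 4 (beyond the scatter) but a number 0.34 log units lower from compound 3 to compound 4 (beyond the scatter) so compound 4 lands in the middle of the series, clear of all three relatives. Among these four compounds, the ethynyl of compound 3 still gives the highest number. No measured evidence is available to explain these steps. Going by these compounds, it remains open where phenyl, an amine or a carboxylic acid would fall at this same place, and whether another five-membered aromatic ring, such as thiophene, would behave like furan-2-yl.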